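Fluorophenyl for methylphenyl on the triazole nitrogen

A few compounds are considered here, and "the series" means these few. Any claim that something is new, unique, unknown or untested is made for them only; others in the source may bear on it.

Compound 1 `O=c1[nH]cc(S(=O)(=O)Nc2ccccc2-c2cn(-c3ccccc3)nn2)c(=O)[nH]1` opens a small set of uracil sulfonamides bearing a phenyl-substituted triazole. In an ADME assay on L02 cells (Homo sapiens) for cytotoxicity, read by MTT assay, with a stated time of 24 h (on this read-out higher numbers stand for lower toxicity in this test and lower numbers for higher toxicity in this test), compound 1 gives 10600 nM. Compound 2 `O=c1[nH]cc(S(=O)(=O)Nc2ccccc2-c2cn(-c3cccc(Cl)c3)nn2)c(=O)[nH]1` carries a chlorinated ring on the triazole nitrogen. For compound 2 this assay reports only a limit of > 100000 nM. The change is an at least 9.4-fold higher number from compound 1 to compound 2 (0.97 log units; beyond the scatter), and it can be stated only as a lower bound because the limit of > 100000 nM in this assay, at which 1 of the 3 values shown sits, is where compound 2 sits. Compound 3 `Cc1ccccc1-n1cc(-c2cccc(NS(=O)(=O)c3c[nH]c(=O)[nH]c3=O)c2)nn1` places the sulfonamide differently on the central benzene and carries a 2-methylphenyl on the triazole nitrogen; in this assay compound 3 gives 15300 nM, which lies within the usual scatter of compound 1.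

Compound 4 `O=c1[nH]cc(S(=O)(=O)Nc2cccc(-c3cn(-c4ccc(F)cc4)nn3)c2)c(=O)[nH]1` keeps the core of compound 3 and differs only by 4-fluorophenyl in place of 2-methylphenyl on an aromatic nitrogen. Going by the values given here, the one measured step, from a plain phenyl to a chlorinated one, brought a clear rise in this number, but no measured pair exchanges a methyl for a fluorine, so the step is expected to be small or modest. The expected step is a 1.4-fold higher number from compound 3 to compound 4 (0.16 log units; within the scatter). Compound 4 is estimated at 22000 nM, with a range from 8000 nM to 70000 nM.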

Compound 4, half-maximal cytotoxic concentration: "not toxic" (no number reported)
Compound 4 has no reported number here, so the estimate cannot be set against anything.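

In this assay, going by these compounds alone, compound 4 is recorded only as "not toxic", with no number, so no step from compound 3 to compound 4 can be read. The compounds shown leave open how far 4-fluorophenyl and 2-methylphenyl on the shared core differ on this read-out, and nothing given here bears on the result for compound 4.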